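Working notes: capping the amino group of compound 2

The source may report more compounds than this note shows. Statements on the series, on what has been measured and on what is new or still open speak of the compounds shown alone.

Compound 1 `OC(c1ccc(Cl)cc1)(c1cccnc1)c1cncs1` is reported in an ADME assay on L6 cells (Rattus norvegicus) for cytotoxicity, read by resazurin assay, with a stated time of 72 h (a higher number here means a weaker inhibitor, a lower number a stronger inhibitor), only as a limit, > 100000 nM. Among the compounds with values here, compound 2 `Nc1ncc(C(O)(c2ccc(Cl)cc2)c2cccnc2)s1` gives 56000 nM, the only actual number so far. Within the data shown here, the one measured step is an at least 1.7-fold lower number from compound 1 to compound 2 (0.25 log units; that floor lies within the scatter), with amino in place of hydrogen on an aromatic carbon. On these data alone, that step starts from the limit of > 100000 nM in this assay, at which 1 of the 2 values shown sits, so its true size stays open.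

Compound 3 `CC(C)C(=O)Nc1ncc(C(O)(c2ccc(Cl)cc2)c2cccnc2)s1` carries isopropylcarbonyl in place of hydrogen on a nitrogen on an aromatic ring. Among the measured compounds shown here, no measured step covers this change, and the step to compound 2 bears on it only by adding the same amino group. No step beyond the scatter is expected in this assay, in either direction, and a result at the limit is possible. For compound 3 the estimated value is 50000 nM, within an expected range of 18000 nM to 100000 nM. The expected change is a 1.1-fold lower number from compound 2 to compound 3 (0.05 log units; within the scatter).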

Compound 3, half-maximal inhibitory concentration: 56600 nM
Estimate against measurement, compound 3: 1.1-fold (0.05 log units) below; low and high end bracket the measured number.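

In this assay, capping the amino group with isopropylcarbonyl gives no step beyond the scatter: a 1.0-fold higher number from compound 2 to compound 3 (0.00 log units; within the scatter). Within the data shown here, this is the first reading of a change on the nitrogen itself, and it shows that this position on the aromatic ring takes an acyl group with five heavy atoms while the number stays within the scatter of compound 2. The comparison with the uncapped, amino-free end of the series, an at least 1.7-fold lower number from compound 1 to compound 3 (0.24 log units; that floor lies within the scatter), gives only a floor, and its true size stays open: the limit of > 100000 nM in this assay, at which 1 of the 3 values shown sits.

On these data alone, one acyl group sets no trend at this nitrogen, so whether a longer chain or a benzoyl group would also stay within the scatter remains open. The same holds for a plain methyl group on this nitrogen, without the carbonyl.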